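Swapping the aryl group at a solubility limit

The source may report more compounds than this note shows. Statements on the series, on what has been measured and on what is new or still open speak of the compounds shown alone.

In a physicochemical assay for solubility, in phosphate buffer, measured as kinetic solubility, at pH 7.4 (a lower number here means a less soluble compound, a higher number a more soluble compound), compound 1 `Cc1oc(-c2ccc(Cl)cc2)nc1CN1CCC(C(=O)NCCCN2C[C@H](C)C[C@H](C)C2)CC1` gives > 72 ug/mL as its reading, which is a limit of the assay and not a number. Compound 2 `Cc1cccc(F)c1-c1nc(CN2CCC(C(=O)NCCCN3C[C@H](C)C[C@H](C)C3)CC2)c(C)o1` gives > 72 ug/mL as its reading, again a limit and not a number. Compound 2 therefore has no exact place on the scale, and its standing is the limit of > 72 ug/mL in this assay, at which 2 of the 2 values shown sit, for now.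

Compound 3 `Cc1cccc(-c2nc(CN3CCC(C(=O)NCCCN4C[C@H](C)C[C@H](C)C4)CC3)c(C)o2)c1` differs from compound 2 in one place (3-methylphenyl in place of 2-fluoro-6-methylphenyl on an aromatic carbon), with 3-methylphenyl in place of 2-fluoro-6-methylphenyl on an aromatic carbon. For the measured compounds named here, only one measured step bears on this change. The swap of 4-chlorophenyl for 2-fluoro-6-methylphenyl is a step that the two limits leave unreadable from compound 1 to compound 2 and so offers no size to carry forward. Because a step that the two limits leave unreadable from compound 1 to compound 2 has no readable size, no step beyond the scatter and no direction is expected in this assay here. The estimated change is a step that the limit leaves unreadable from compound 2 to compound 3 in this reading. Compound 3 is estimated at 75 ug/mL with an expected range (45 ug/mL to 95 ug/mL).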

Compound 3, solubility: > 69 ug/mL
Compound 3: a limit, no number; the forecaster's own chance of this, stated with the estimate: 75%; the middle value is on the limit's open side.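

For the compounds shown here, compound 1, compound 2 and compound 3 all give limits of the assay and not numbers, and no step between them can be read. Still open, going by these compounds, is how far the solubility of each compound lies past its limit, and whether 4-chlorophenyl, 2-fluoro-6-methylphenyl and 3-methylphenyl give different solubilities at all.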